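From 4-Bromophenyl to 2-Chlorophenyl

The source may hold more compounds than are shown below. What is called first, only, known or untested is meant among the compounds shown, and "the series" means these compounds.

In a physicochemical assay for lipophilicity, measured as octanol-water partition (a higher number here means a more lipophilic compound, a lower number a more polar compound), compound 1 (`O=C(COc1cccc2ccccc12)N/N=C/c1ccc(Br)cc1`) gives 4.81 and stands highest of the three measured numbers, ahead of compound 2 (`O=C(COc1cccc2ccccc12)N/N=C/c1ccc([N+](=O)[O-])cc1`) at 3.97 and compound 3 (`C/C(=N\NC(=O)COc1cccc2ccccc12)c1ccccc1O`) at 3.08 on the same scale. Compound 4 (`O=C(COc1cccc2ccccc12)N/N=C/c1ccccc1Cl`) has no number yet. It carries 2-chlorophenyl in place of 4-bromophenyl on a carbon with a double bond to nitrogen. Going by the values given here, one measured step bears on this: with nitro in place of bromo, the result was a number 0.84 log units lower from compound 1 to compound 2 (beyond the scatter) in the same series. Among the compounds with values here, no measured step shows chlorine replacing bromine, so that step guides size only. A much smaller downward shift is expected, estimated as a number 0.26 log units lower from compound 1 to compound 4 (within the scatter) in this assay and possibly no more than scatter. Compound 4 is therefore estimated at 4.55 with a range from 4.15 to 4.95 on this scale.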

Compound 4, partition coefficient: 4.54
Compound 4: the middle estimate sits 0.01 log units above what was measured; the range from low to high includes it.
By their numbers in this assay, from the lowest: compound 3; then compound 2; then compounds 4 and 1 (each within the scatter of the next).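

Putting 2-chlorophenyl in place of 4-bromophenyl on this carbon gives a number 0.27 log units lower from compound 1 to compound 4 (within the scatter) in this assay and so leaves the reading within the scatter, unlike the nitro step, a number 0.84 log units lower from compound 1 to compound 2 (beyond the scatter), which lies beyond it. The halogen and its place on the ring changed together, so this single step cannot separate the two. No measurement here offers an explanation for this result. As far as these compounds go, whether an amine or a carboxylic acid on this phenyl ring would move the number remains open.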